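Thiocarbamate series: amine swap at the thiocarbonyl

The source may hold more compounds than are shown below. What is called first, only, known or untested is meant among the compounds shown, and "the series" means these compounds.

Within the data shown here, compound 1 `O=c1c(CSC(=S)N2CCCC2)coc2ccccc12` gives 3800 nM in a functional assay on MDA-MB-435S cells (Homo sapiens) for antiproliferative activity, read by MTT assay, with a stated time of 72 h (on this read-out higher numbers stand for weaker inhibition and lower numbers for stronger inhibition), the second highest of the three numbers so far. Compound 2 `COc1ccc2occ(CSC(=S)N3CCCC3)c(=O)c2c1` gives 1800 nM in this assay, and compound 3 `O=c1c(CSC(=S)N2CCCC2)coc2cc(Cl)ccc12` gives 6400 nM. The step of a 2.1-fold lower number from compound 1 to compound 2 (0.32 log units; beyond the scatter) is modest, while the step of a 1.7-fold higher number from compound 1 to compound 3 (0.23 log units; within the scatter) stays within the scatter; both alter the aromatic ring and leave the amine untouched. Compound 4 `CC(C)N(C(=S)SCc1coc2ccccc2c1=O)C(C)C` differs from compound 1 by diisopropylamino in place of pyrrolidin-1-yl on a thiocarbonyl carbon. Among the measured compounds shown here, no measured step varies this part of the structure, so the measured compounds give no direction for the change, and no step beyond the scatter is expected. For compound 4 the estimate is 3800 nM with range 1500 nM to 9500 nM, amounting to an expected no change at the digits printed from compound 1 to compound 4 (within the scatter).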

Compound 4, half-maximal inhibitory concentration: 7900 nM
Compound 4: middle estimate off by 2.1-fold (0.32 log units), on the low side, within the range that was stated.
By their numbers in this assay, from the lowest: compound 2; then compounds 1, 3 and 4 (each within the scatter of the next, the first and the last beyond it).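

In this assay the amine on the thiocarbonyl carbon proves not to be a silent position, with a 2.1-fold higher number from compound 1 to compound 4 (0.32 log units; beyond the scatter) on replacing the pyrrolidin-1-yl ring with open-chain diisopropylamino. This single pair gives a direction for this one change only. Nothing available accounts for the step.

Open, going by these compounds, is whether the shift goes with loss of the ring or with the branched chains; diethylamino or piperidin-1-yl on the core of compound 1 would separate the two. Also open, on these data alone, is whether the methoxy step of compound 2 carries over to the diisopropylamino compound.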